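The compounds below may be only part of what the source reports. "The series", "measured", "known", "first", "only" and "open" are said of these compounds alone.

Measured in an assay on HEK293 cells for displacement of a labelled ligand from NPC1-like intracellular cholesterol transporter 1 (Homo sapiens); on this read-out lower numbers stand for stronger inhibition and higher numbers for weaker inhibition:
compound 1 `O=C(CN1CN(c2ccccc2)C2(CCN(C(=O)c3ccc(C4CCCCC4)cc3)CC2)C1=O)N1CCCCC1`: 1100 nM
compound 2 `CC1CCCN(C(=O)CN2CN(c3ccccc3)C3(CCN(C(=O)c4ccc(C5CCCCC5)cc4)CC3)C2=O)C1`: 3600 nM
compound 3 `CS(=O)(=O)N1CCN(C(=O)CN2CN(c3ccccc3)C3(CCN(C(=O)c4ccc(C5CCCCC5)cc4)CC3)C2=O)CC1`: 6300 nM

Compound 3 gives the highest of the three numbers; the steps of a 5.7-fold higher number from compound 1 to compound 3 (0.76 log units; beyond the scatter) and a 1.8-fold higher number from compound 2 to compound 3 (0.24 log units; within the scatter) set it furthest from compound 1 and close to compound 2.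

Compound 4 `COC(=O)CCNC(=O)CN1CN(c2ccccc2)C2(CCN(C(=O)c3ccc(C4CCCCC4)cc3)CC2)C1=O` differs from compound 3 by (2-(methoxycarbonyl)ethyl)amino in place of 4-(methylsulfonyl)piperazin-1-yl on a carbonyl carbon. Among the measured compounds shown here, the steps that touch this carbonyl carbon are a 5.7-fold higher number from compound 1 to compound 3 (0.76 log units; beyond the scatter) and a 1.8-fold higher number from compound 2 to compound 3 (0.24 log units; within the scatter); both moved the number upward by a modest amount at most, and no measured pair covers an open-chain group at this place. The step of a 1.3-fold lower number from compound 3 to compound 4 (0.10 log units; within the scatter) is expected to stay within the scatter, direction uncertain. For compound 4 the estimate in this assay is 5000 nM, range 1500 nM to 16000 nM.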

Compound 4, half-maximal inhibitory concentration: 12900 nM
Compound 4: middle estimate off by 2.6-fold (0.41 log units), on the low side, and the stated range covers the measured number.
By their numbers in this assay, from the lowest: compound 1; then compounds 2 and 3 (each within the scatter of the next); then compound 4.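

Among the compounds shown here, the open-chain (2-(methoxycarbonyl)ethyl)amino group on this carbonyl carbon, the only group here with no ring and with a hydrogen-bond donor, gives a higher number than each ring group (a 2.0-fold higher number from compound 3 to compound 4 (0.31 log units; beyond the scatter)) (a 3.6-fold higher number from compound 2 to compound 4 (0.55 log units; beyond the scatter)) (a 12-fold higher number from compound 1 to compound 4 (1.07 log units; beyond the scatter)). For the compounds shown here, only the last step is large, and it sets the widest gap at this position so far. No measured evidence bears on this rise.

With one open-chain group, the chain, the amide hydrogen and the methyl ester cannot be told apart. Going by these compounds, the carboxylic acid, a longer chain and the N-methyl amide of this chain remain open.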